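This account rests on a few compounds, and the source may have more. Where it says the series, first, only, none or still open, it means among the compounds named here.

Compound 1, `C=CC1=C(C(=O)NCc2ccc(Cl)cc2)C(c2ccc(OC)c(OC)c2)OC1`: > 100000 nM
Compound 2, `C=CC1=C(C(=O)NCc2ccc(Cl)cc2)C(c2ccc(OC)cc2)OC1`: > 100000 nM
Compound 3, `C=CC1=C(C(=O)NCc2ccccc2F)C(c2ccc(F)cc2)OC1`: 51400 nM

Of the compounds shown here, three sharing one core have been tested in a functional assay on QGY7701 cells (Homo sapiens) for cytotoxicity, read by MTT assay, with a stated time of 24 h; a lower number here means a stronger inhibitor, a higher number a weaker inhibitor. Compound 2 gives only a limit of the assay there, > 100000 nM, and no number. Compound 1 likewise sits at a limit, > 100000 nM. The change from compound 1 to compound 2, hydrogen in place of methoxy on an aromatic carbon, therefore gives a step that the two limits leave unreadable from compound 1 to compound 2; both values are limits, and the size of that step cannot be read, a point also made by the limit of > 100000 nM in this assay, at which 2 of the 3 values shown sit. For the measured compounds named here, compound 3 is the one compound with a measured number, giving 51400 nM in this assay.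

Compound 4, `C=CC1=C(C(=O)Nc2ccccc2)C(c2ccc(OC)cc2)OC1`, is not yet measured. It differs from compound 2 by phenyl in place of 4-chlorobenzyl on an amide-type nitrogen. Going by the values given here, no measured step touches this amide-type nitrogen; the only step on record concerns an aromatic methoxy and is unreadable in size, so nothing measured bears on the change at hand.

Given that compound 2 shows only a limit, compound 4 is estimated at 100000 nM, in the range 30000 nM to 300000 nM. The expected step from compound 2 is a number no higher from compound 2 to compound 4 (the limit leaves the size open), most likely a further limit rather than a number.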

Compound 4, half-maximal inhibitory concentration: > 100000 nM
Compound 4 gave a limit, no number; the forecaster's own chance of this, stated with the estimate: 60%; the middle value lies on the limit itself.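

In this assay compound 4 gives > 100000 nM, a limit and not a number. Compound 2 also stands at a limit, and the step between compound 2 and compound 4 cannot be read. The compounds shown leave open what phenyl in place of 4-chlorobenzyl does to the value.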